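A few compounds are considered here, and "the series" means these few. Any claim that something is new, unique, unknown or untested is made for them only; others in the source may bear on it.

Measured compounds:

Compound 1, `COc1ccc(C(=O)/C=C/c2ccccc2)cc1[N+](=O)[O-]`. In a functional assay on B16 cells (Mus musculus) for cytotoxicity, read by MTT assay, with a stated time of 3 days (on this read-out lower numbers stand for stronger inhibition and higher numbers for weaker inhibition), compound 1 gives > 100000 nM, which is a limit of the assay rather than a number.

Compound 2, `COc1ccc(C(=O)/C=C/c2ccccc2)cc1N`. In this assay compound 2 gives > 100000 nM, again a limit of the assay and not a number.

Compound 3, `COc1ccc(OC)c(C(=O)/C=C/c2ccc(OC)c([N+](=O)[O-])c2)c1`. In this assay compound 3 gives > 100000 nM, also a limit of the assay and not a number.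

Compound 1 and compound 2 differ in one place only: amino in place of nitro on an aromatic carbon. The step that the two limits leave unreadable from compound 1 to compound 2 cannot be read, since both values sit at the same limit, as the limit of > 100000 nM in this assay, at which 3 of the 3 values shown sit, shows. Compound 3 is built on a different core; how the core of compound 3 differs from the core of compound 1 is not broken down here.

Compound 4, `COc1ccc(OC)c(C(=O)/C=C/c2ccc(OC)c(N)c2)c1`, has not yet been measured in this assay. It differs from compound 3 by amino in place of nitro on an aromatic carbon, the same kind of change as that from compound 1 to compound 2, and the surroundings of the place are described in the same words in both cases. The earlier step that the two limits leave unreadable from compound 1 to compound 2 gives no readable size, so the expectation for compound 4 rests only on the fact that every measured compound sits at the limit described by the limit of > 100000 nM in this assay, at which 3 of the 3 values shown sit. The step from compound 3 to compound 4 is therefore expected to be a step that the limit leaves unreadable from compound 3 to compound 4, with compound 4 most likely remaining at the limit as well. Compound 4 is estimated at 150000 nM, within an expected range from 40000 nM to 600000 nM.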

Compound 4, half-maximal inhibitory concentration: 2000 nM
Beside the measured number, compound 4's estimate is 75-fold (1.88 log units) above it; measured number below the stated range.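

In this assay, amino in place of nitro on an aromatic carbon, ortho to a methoxy group, gives an at least 50-fold lower number from compound 3 to compound 4 (1.69 log units; beyond the scatter), so on the core of compound 3 this single change is followed by a large drop that lies beyond the scatter. As far as these compounds go, compound 3 gives > 100000 nM, which is a limit of the assay and not a number, so the true size of this step stays unknown. On the core of compound 1 the same change leaves compound 2 at the limit, and that step cannot be read: it shows that the result on the core of compound 3 does not carry over to the core of compound 1 to the point of giving a readable number there, but not that the change has no effect on that core, nor which feature of either core is responsible, as the evidence here is only this: the limit of > 100000 nM in this assay, at which 3 of the 4 values shown sit.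

The compounds shown leave open which part of the core of compound 3 the result depends on, as the two cores are compared through this single pair of steps alone. They also leave open whether the result belongs to the amino group itself or would also appear with a hydroxyl group, a dimethylamino group or an acetamide in the same place.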